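The source may hold more compounds than are shown below. What is called first, only, known or untested is meant among the compounds shown, and "the series" means these compounds.

In an assay on CHO cells for displacement of a labelled ligand from adenosine receptor A1 (Homo sapiens), read by scintillation counting, with a stated time of 120 min, tested at 10 uM (on this read-out lower numbers stand for less inhibition and higher numbers for more inhibition at the one concentration tested (going by the name of the read-out)), the three measured compounds stand as follows:

Compound 1, `Nc1scc(CN2CCN(c3ccccc3C(F)(F)F)CC2)c1C(=O)c1ccc(Cl)cc1`: 0%
Compound 2, `Nc1scc(CN2CCN(c3ccc(Cl)c(C(F)(F)F)c3)CC2)c1C(=O)c1ccc(Cl)cc1`: 0%
Compound 3, `Nc1scc(CN2CCN(C3CCCCCC3)CC2)c1C(=O)c1ccc(Cl)cc1`: 0%

Compound 3 thus sits level with compounds 1 and 2; none of the three shows any measurable displacement of the labelled ligand at the single concentration tested, and every step among them lies within the scatter.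

Compound 4, `Nc1scc(CN2CCN(c3cccc4ccccc34)CC2)c1C(=O)c1ccc(Cl)cc1`, differs from compound 3 in one place: naphthalen-1-yl in place of cycloheptyl on an amine nitrogen in a ring. Among the compounds with values here, the steps that bear on this change are no change at the digits printed from compound 1 to compound 3 (within the scatter) and no change at the digits printed from compound 2 to compound 3 (within the scatter), each of which replaced an aromatic group on the same ring nitrogen by cycloheptyl without effect. The step of no change at the digits printed from compound 1 to compound 2 (within the scatter) shows that exchanging one aromatic group for another on that nitrogen also left the read-out unchanged. Putting naphthalen-1-yl back in place of cycloheptyl is therefore expected to produce no step beyond the scatter, that is no change at the digits printed from compound 3 to compound 4 (within the scatter). For compound 4 the estimated value in this assay is 0%, with a range from -10% to 12%.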

Compound 4, a percentage reported as inhibition, at one concentration (the size of the read-out at that concentration, not a potency): 1%
The estimate for compound 4 lay 1 percentage points below the measured number, within the range that was stated.
By their numbers in this assay, from the lowest: compounds 1, 2, 3 and 4 (each within the scatter of the next).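

In this assay, a group with 2 six-membered aromatic rings on the ring nitrogen, naphthalen-1-yl, does no more than cycloheptyl does, giving a number 1 percentage points higher from compound 3 to compound 4 (within the scatter). The same holds when it stands in place of either trifluoromethyl-bearing phenyl group, with a number 1 percentage points higher from compound 2 to compound 4 (within the scatter) and a number 1 percentage points higher from compound 1 to compound 4 (within the scatter), so four quite different groups at this position now read alike at the one concentration tested. Nothing measured here explains this flat result.

Going by these compounds, all four values sit at the floor of the read-out, so they cannot rank these groups, and it remains open whether any group on this nitrogen gives real inhibition, such as a benzyl group, a short alkyl chain or a carboxylic acid. Also open, on these data alone, is whether changes elsewhere on the shared core would do so.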